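The source may hold more compounds than are shown below. What is called first, only, known or untested is meant among the compounds shown, and "the series" means these compounds.

The two measured compounds share one core and differ only in the group on an amine nitrogen. Compound 1, `Cc1cn([C@@H]2O[C@H](CO[Si](C)(C)C(C)(C)C)[C@@]3(OS(=O)(=O)C=C3NCC(N)=O)[C@H]2O[Si](C)(C)C(C)(C)C)c(=O)n(C)c1=O`, gives 14600 nM in a functional assay on CCRF-CEM cells (Homo sapiens); a higher number here means that more compound is tolerated, a lower number that less compound is tolerated. Compound 2, `CCOC(=O)NC(=O)NC1=CS(=O)(=O)O[C@@]12[C@@H](CO[Si](C)(C)C(C)(C)C)O[C@@H](n1cc(C)c(=O)n(C)c1=O)[C@@H]2O[Si](C)(C)C(C)(C)C`, gives 3000 nM in the same assay, which is the lowest of the two numbers; the change from carbamoylmethyl to (ethoxycarbonyl)carbamoyl gave a 4.9-fold lower number from compound 1 to compound 2 (0.69 log units; beyond the scatter).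

Compound 3, `COC(=O)C(=O)CNC1=CS(=O)(=O)O[C@@]12[C@@H](CO[Si](C)(C)C(C)(C)C)O[C@@H](n1cc(C)c(=O)n(C)c1=O)[C@@H]2O[Si](C)(C)C(C)(C)C`, is the next compound in the series and has not yet been measured. It differs from compound 2 by ((methoxycarbonyl)carbonyl)methyl in place of (ethoxycarbonyl)carbamoyl on an amine nitrogen. For the measured compounds named here, only one measured step exists, the one from compound 1 to compound 2, and it concerns a different pair of groups at the same amine nitrogen, so it bears on the new change only loosely: it shows that exchanging the substituent at this position can shift the number by a modest but real amount. Since the new group has no hydrogen-bond donor where the old one had one, a drift back toward the number of compound 1 seems as likely as no change beyond the scatter. Compound 3 is therefore expected to lie at 6000 nM, within the range 2000 nM to 20000 nM, which means an expected step of a 2.0-fold higher number from compound 2 to compound 3 (0.30 log units; within the scatter).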

Compound 3, half-maximal cytotoxic concentration: 5570 nM
The estimate for compound 3 lay 1.1-fold (0.03 log units) above the measured number; the range from low to high includes it.
By their numbers in this assay, from the lowest: compounds 2 and 3 (each within the scatter of the next); then compound 1.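

In this assay, ((methoxycarbonyl)carbonyl)methyl in place of (ethoxycarbonyl)carbamoyl on the amine nitrogen gave a 1.9-fold higher number from compound 2 to compound 3 (0.27 log units; within the scatter), so this pair cannot be told apart, even though the entering group has 0 hydrogen-bond donors and the leaving group has 1 hydrogen-bond donor. Methoxycarbonyl in place of amino on a carbonyl carbon gave a 2.6-fold lower number from compound 1 to compound 3 (0.42 log units; beyond the scatter), which shows that the separation from compound 1 is not confined to the (ethoxycarbonyl)carbamoyl group, since two differently built groups now stand apart from compound 1 by more than the scatter. No measurement at hand explains these differences.

Going by these compounds, whether a carboxylic acid in place of methoxycarbonyl, or a longer chain on the amine nitrogen, would move the number beyond the scatter remains open. On these data alone, how an unsubstituted amine at this position compares with all three substituted compounds also remains open, and so does whether any group here can lie outside the span these three compounds cover.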